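The source may report more compounds than this note shows. Statements on the series, on what has been measured and on what is new or still open speak of the compounds shown alone.

Values in an ADME assay on the whole organism (strain CD-1) for pharmacokinetics, with Mus musculus as the target, at a dose of 3 mg/kg by the intravenous route (a higher number here means more compound in the circulation at the dose given, a lower number less compound in the circulation), for the series
compound 1 `CN(Cc1ccccc1OCCCCCC(=O)O)C(=O)c1ccc(-c2ccco2)cc1` gives 1100 ng.h/mL
compound 2 `CN(Cc1ccccc1OCCCCC(C)(C)C(=O)O)C(=O)c1ccc(-c2ccco2)cc1` gives 48400 ng.h/mL
compound 3 `C[C@@H](CCCOc1ccccc1CN(C)C(=O)c1ccc(-c2ccco2)cc1)CC(=O)O` gives 30800 ng.h/mL

Compound 3 cannot be separated from compound 2, with a 1.6-fold lower number from compound 2 to compound 3 (0.20 log units; within the scatter) as the gap. Compound 1 lies far off, as a 44-fold higher number from compound 1 to compound 2 (1.64 log units; beyond the scatter) and a 28-fold higher number from compound 1 to compound 3 (1.45 log units; beyond the scatter) show. Compound 4 `CN(Cc1ccccc1OCCC[C@@H]1C[C@@H]1C(=O)O)C(=O)c1ccc(-c2ccco2)cc1` comes next, with 2-carboxycyclopropyl in place of 1-(carboxymethyl)ethyl on a saturated chain carbon, three bonds along the chain from an oxygen on an aromatic ring as its change: 2-carboxycyclopropyl in place of 1-(carboxymethyl)ethyl on a saturated chain carbon, three bonds along the chain from an oxygen on an aromatic ring. Among the compounds with values here, no measured step introduces a ring. The differing chain groups of compound 2 at 48400 ng.h/mL and compound 3 at 30800 ng.h/mL stay close, so no step beyond the scatter is expected in this assay here. The expected step is a 1.5-fold lower number from compound 3 to compound 4 (0.19 log units; within the scatter) on this estimate. The estimate for compound 4 is 20000 ng.h/mL with an expected range from 6000 ng.h/mL to 55000 ng.h/mL in this measurement.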

Compound 4, area under the concentration-time curve: 30100 ng.h/mL
For compound 4 the middle estimate is 1.5-fold (0.18 log units) below the measured one; low and high end bracket the measured number.
By their numbers in this assay, from the lowest: compound 1; then compounds 4, 3 and 2 (each within the scatter of the next).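

In this assay, within the data shown here, a ring enters this position for the first time, and the 2-carboxycyclopropyl group keeps the level of the branched chains, with a 1.0-fold lower number from compound 3 to compound 4 (0.01 log units; within the scatter) and a 1.6-fold lower number from compound 2 to compound 4 (0.21 log units; within the scatter) both inside the scatter. The gain over the unbranched chain of compound 1 is thus not confined to methyl branching, as a 27-fold higher number from compound 1 to compound 4 (1.44 log units; beyond the scatter) shows for the ring. No measurement at hand accounts for this shared level.

Still open, on these data alone, is whether a four-membered carbon ring would hold this level, or a primary amide in place of the carboxylic acid. As far as these compounds go, the other stereoisomers of 2-carboxycyclopropyl also remain open.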